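Moving the benzyl halogen: what to expect for compound 4

The compounds below may be only part of what the source reports. "The series", "measured", "known", "first", "only" and "open" are said of these compounds alone.

Measured so far:
- compound 1, `COc1cc(OC)c(-c2coc3cc(OCc4ccccc4F)ccc3c2=O)cc1OC`: in a functional assay on U-251 cells (Homo sapiens) for antiproliferative activity, read by MTT assay, with a stated time of 24 h (a lower number here means a stronger inhibitor, a higher number a weaker inhibitor), compound 1 gives 2890 nM
- compound 2, `COc1cc(OC)c(-c2coc3cc(OCc4ccccc4C(F)(F)F)ccc3c2=O)cc1OC`: compound 2 reaches only the limit of the assay, > 10000 nM
- compound 3, `COc1cc(OC)c(-c2coc3cc(OCc4ccccc4Cl)ccc3c2=O)cc1OC`: compound 3 likewise stops at the limit, > 10000 nM

Compound 1 is the only one of the three with a number; the other two values are limits, not numbers, as the limit of > 10000 nM in this assay, at which 2 of the 3 values shown sit, records. Compound 4, `COc1cc(OC)c(-c2coc3cc(OCc4cccc(Br)c4)ccc3c2=O)cc1OC`, differs from compound 1 in one place: 3-bromophenyl in place of 2-fluorophenyl on a saturated chain carbon bound to an oxygen on an aromatic ring. For the measured compounds named here, two measured steps bear on this, both starting from compound 1 and both changing the halogen on that same benzyl ring: an at least 3.4-fold higher number from compound 1 to compound 2 (0.53 log units; beyond the scatter) and an at least 3.4-fold higher number from compound 1 to compound 3 (0.53 log units; beyond the scatter). Each of them pushed the value beyond the limit, so every change to this ring seen so far weakened the compound. Compound 4 carries both a different halogen and a different position, and a weaker result is therefore expected, of about a 3.1-fold higher number from compound 1 to compound 4 (0.49 log units; beyond the scatter). For compound 4 the estimate is 9000 nM, expected within 3000 nM to 30000 nM, with a fair chance that only a limit is reported.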

Compound 4, half-maximal inhibitory concentration: > 10000 nM
Compound 4: only a limit was reported; the forecaster's own chance of this, stated with the estimate: 45%; at least 1.1-fold (0.04 log units) between middle value and limit.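

In this assay, compounds 2 and 3 changed the group on the benzyl ring, and compound 4 extends this by changing both the halogen and its place on that ring, again with a loss of activity: an at least 3.4-fold higher number from compound 1 to compound 4 (0.53 log units; beyond the scatter). Because both changed at once, this result cannot show which change matters, and compound 1 remains the only one of the four with a number. The steps from compound 2 to compound 4 and from compound 3 to compound 4 cannot be read, with limits at both ends: the limit of > 10000 nM in this assay, at which 3 of the 4 values shown sit.

On these data alone, it remains open how 2-bromophenyl or 3-fluorophenyl would read, and either could help separate the halogen from its place. As far as these compounds go, it is also open whether a methoxy group or an amine on this ring would give a number rather than a limit.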